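The compounds below may be only part of what the source reports. "The series", "measured", "known", "first", "only" and "open" are said of these compounds alone.

Measured in an ADME assay on L1210/0 cells (Mus musculus) for cytotoxicity, with a stated time of 48 h; a lower number here means a stronger inhibitor, a higher number a weaker inhibitor:

Compound 1 `N#Cc1cn([C@H]2C[C@H](O)[C@@H](CO)O2)c(=O)[nH]c1=O`: > 200000 nM
Compound 2 `O=c1[nH]c(=O)n([C@H]2C[C@H](O)[C@@H](CO)O2)cc1C#CCCO`: > 200000 nM
Compound 3 `CCCc1cn([C@H]2C[C@H](O)[C@@H](CO)O2)c(=O)[nH]c1=O`: > 200000 nM

None of these entries is a number. Compound 3 stands at > 200000 nM, which is a limit of the assay. The other two entries are limits as well, so the whole series sits at one point: the limit of > 200000 nM in this assay, at which 3 of the 3 values shown sit.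

The next compound to be tested is compound 4 `O=c1[nH]c(=O)n([C@H]2C[C@H](O)[C@@H](CO)O2)cc1/C=C/Cl`. Going from compound 3 to compound 4, 2-chloroethenyl comes in place of propyl on an aromatic carbon (2-chloroethenyl in place of propyl on an aromatic carbon).

Among the measured compounds shown here, three measured steps touch this same carbon. They are a step that the two limits leave unreadable from compound 1 to compound 2, a step that the two limits leave unreadable from compound 1 to compound 3 and a step that the two limits leave unreadable from compound 2 to compound 3. None of them gives a size or a direction to carry over, and the series holds no measured number for any group at this carbon. For the measured compounds named here, no step of known size is therefore expected in this assay, and the likeliest outcome is that compound 4 also returns only a limit. A measurable value close to that limit remains possible.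

The step expected is a number no higher from compound 3 to compound 4 (the limit leaves the size open). Compound 4 is estimated at 200000 nM, with an expected range from 50000 nM to 400000 nM.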

Compound 4, half-maximal inhibitory concentration: > 200000 nM
Compound 4: only a limit was reported; the forecaster's own chance of this, stated with the estimate: 65%; the middle value sits exactly at the limit.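

In this assay compound 4 gives > 200000 nM, which is a limit and not a number. The steps linking compound 4 to compound 1, compound 2 and compound 3 cannot be read, because the series stays at a single point: the limit of > 200000 nM in this assay, at which 4 of the 4 values shown sit.

The compounds shown leave open whether any group on this aromatic carbon gives a measurable value, and how such groups would rank.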